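The source may report more compounds than this note shows. Statements on the series, on what has been measured and on what is new or still open speak of the compounds shown alone.

Compounds measured so far:
- compound 1, `Cc1cccc(-c2cccc(OC(=O)NC3CCCCC3)c2)c1`: 61.8 nM
- compound 2, `O=C(NC1CCCCC1)Oc1cccc(-c2cccc(F)c2)c1`: 96.6 nM
- compound 3, `O=C(NC1CCCCC1)Oc1cccc(-c2cccc(OC(=O)NC3CCCCC3)c2)c1`: 361 nM

In an assay on cell membranes for binding affinity to Fatty-acid amide hydrolase 1 (Rattus norvegicus) (a higher number here means a weaker inhibitor, a lower number a stronger inhibitor), compound 3 gives the highest number of the three, with compound 2 nearest and compound 1 furthest. Compound 4, `O=C(NC1CCCCC1)Oc1cccc(-c2cccc(Oc3ccccc3)c2)c1`, is not yet measured; it differs from compound 3 by phenyl in place of cyclohexylcarbamoyl on an oxygen on an aromatic ring.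

For the measured compounds named here, no measured step introduces a phenoxy group, so the step from compound 3 to compound 4 has no direct precedent. What the measured steps do show is the other side of the same position: going from a methyl or a fluoro to the (cyclohexylcarbamoyl)oxy group raised the number, a 5.8-fold higher number from compound 1 to compound 3 (0.77 log units; beyond the scatter) and a 3.7-fold higher number from compound 2 to compound 3 (0.57 log units; beyond the scatter). Compound 4 keeps the oxygen at that position but carries a phenyl on it instead of the cyclohexylcarbamoyl, so it is expected to move away from compound 3 and toward compounds 1 and 2, estimated as a 4.0-fold lower number from compound 3 to compound 4 (0.60 log units; beyond the scatter). Compound 4 is therefore expected to give about 90 nM in this assay, with a likely range from 35 nM to 250 nM.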

Compound 4, half-maximal inhibitory concentration: 420 nM
The estimate for compound 4 lay 4.7-fold (0.67 log units) below the measured number; measured number outside the range, above it.
By their numbers in this assay, from the lowest: compounds 1 and 2 (each within the scatter of the next); then compounds 3 and 4 (each within the scatter of the next).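

In this assay, phenyl in place of cyclohexylcarbamoyl on the oxygen gives a 1.2-fold higher number from compound 3 to compound 4 (0.07 log units; within the scatter), so these two groups cannot be told apart here. Phenoxy compares with the other two groups much as (cyclohexylcarbamoyl)oxy did, with a 4.3-fold higher number from compound 2 to compound 4 (0.64 log units; beyond the scatter) in place of fluoro and a 6.8-fold higher number from compound 1 to compound 4 (0.83 log units; beyond the scatter) in place of methyl. Among these compounds, the higher number therefore does not depend on the cyclohexyl ring, the carbonyl or the hydrogen-bond donor, all of which leave with the cyclohexylcarbamoyl group.

No evidence is available on what sets compounds 3 and 4 apart from compounds 1 and 2. On these data alone, it remains open whether a hydroxyl or a methoxy group at this position would give numbers like those of compounds 3 and 4 or like those of compounds 1 and 2.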